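Swapping a methoxy for a hydroxy on the cyclohexyl ring

This account rests on a few compounds, and the source may have more. Where it says the series, first, only, none or still open, it means among the compounds named here.

Three close relatives of one shared core have been measured in a functional assay on PC-3 cells (Homo sapiens) for inhibition, with a stated time of 72 h; on this read-out lower numbers stand for stronger inhibition and higher numbers for weaker inhibition. Compound 1 `Cc1nc(-c2nc[nH]n2)ccc1-c1cnc2c(n1)N(CCC1CCOCC1)C(=O)CN2` gives 34 nM. Compound 2 `Cc1nc(-c2nc[nH]n2)ccc1-c1cnc2c(n1)N([C@H]1CC[C@@H](O)CC1)C(=O)CN2` gives 37 nM, and compound 3 `CO[C@H]1CC[C@H](N2C(=O)CNc3ncc(-c4ccc(-c5nc[nH]n5)nc4C)nc32)CC1` gives 38 nM. Compound 3 holds the highest of these three numbers, but its gap to compound 2 is within the scatter, and so is its gap to compound 1; nothing separates the three.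

Compound 4 `Cc1nc(-c2nc[nH]n2)ccc1-c1cnc2c(n1)N([C@H]1CC[C@H](O)CC1)C(=O)CN2` differs from compound 3 by hydrogen in place of methyl on an oxygen on a saturated carbon. The step that bears most directly on this change is a 1.0-fold higher number from compound 2 to compound 3 (0.01 log units; within the scatter), where the same two groups, 4-hydroxycyclohexyl and 4-methoxycyclohexyl, are exchanged the other way round. The steps of a 1.1-fold higher number from compound 1 to compound 2 (0.04 log units; within the scatter) and a 1.1-fold higher number from compound 1 to compound 3 (0.05 log units; within the scatter) point the same way: none of the substituents on this amide-type nitrogen has moved the number beyond the scatter.

For compound 4 the expected step is therefore no change at the digits printed from compound 3 to compound 4 (within the scatter), no change beyond the scatter, and the estimate for compound 4 is 38 nM, within a range from 19 nM to 76 nM.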

Compound 4, half-maximal inhibitory concentration: 119 nM
The estimate for compound 4 lay 3.1-fold (0.50 log units) below the measured number; the whole stated range lies below it.
By their numbers in this assay, from the lowest: compounds 1, 2 and 3 (each within the scatter of the next); then compound 4.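

In this assay, for the compounds shown here, the step from methoxy to hydroxy is a 3.1-fold higher number from compound 3 to compound 4 (0.50 log units; beyond the scatter) even though the same two group names gave only a 1.0-fold higher number from compound 2 to compound 3 (0.01 log units; within the scatter), so the substituent on this nitrogen is not as free as the earlier compounds suggested. The step of a 3.2-fold higher number from compound 2 to compound 4 (0.51 log units; beyond the scatter) joins two compounds with identical atoms and bonds, which points to the drawn arrangement on the cyclohexyl ring and not to the hydroxy group alone: the fact that compounds 2 and 4 differ only in the configuration as drawn. The same contrast appears against the 2-(oxan-4-yl)ethyl compound, with a 3.5-fold higher number from compound 1 to compound 4 (0.54 log units; beyond the scatter) for one arrangement and a 1.1-fold higher number from compound 1 to compound 2 (0.04 log units; within the scatter) for the other.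

From the compounds shown here alone, the methoxy group appears in only one arrangement here, so whether configuration matters equally for it remains open. Also open, going by these compounds, is whether the same holds for other groups on this ring carbon, such as an amine or a carboxylic acid.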